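The compounds below may be only part of what the source reports. "The series", "measured", "known", "first", "only" and "open" are said of these compounds alone.

Measured so far:
compound 1, `C=C(CC(O)C(=O)O)C(=O)O`: 300 nM
compound 2, `C=C(CC(O)(C(=O)O)C(F)(F)F)C(=O)O`: 2050 nM

Both numbers come from an assay on isolated protein for binding affinity to methylcytosine dioxygenase TET2 (Homo sapiens), read by microscale thermophoresis; a lower number here means tighter binding, a higher number weaker binding. In this assay compound 1 gives 300 nM, while compound 2 gives 2050 nM, which is the higher of the two numbers and so the weaker binding seen here. Going by the values given here, the one measured step, a 6.8-fold higher number from compound 1 to compound 2 (0.83 log units; beyond the scatter), came with trifluoromethyl in place of hydrogen on a saturated chain carbon bound to a carbonyl carbon, an oxygen on a saturated carbon and a saturated chain carbon.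

Compound 3, `C=C(CC(C)(O)C(=O)O)C(=O)O`, differs from compound 2 in one place: methyl in place of trifluoromethyl on a saturated chain carbon bound to a carbonyl carbon, an oxygen on a saturated carbon and a saturated chain carbon. This change undoes part of the measured step, since a methyl now sits where compound 1 had hydrogen and compound 2 had trifluoromethyl. Among the compounds with values here, with only that one step to go on, a move back toward the number of compound 1 is expected, though not necessarily the whole way. Compound 3 is therefore estimated to give about 750 nM in this assay, within a range of 250 nM to 2200 nM. That estimate corresponds to an expected step of a 2.7-fold lower number from compound 2 to compound 3 (0.44 log units; beyond the scatter).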

Compound 3, dissociation constant: 610 nM
Estimate against measurement, compound 3: 1.2-fold (0.09 log units) above; low and high end bracket the measured number.
By their numbers in this assay, from the lowest: compound 1; then compound 3; then compound 2.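

In this assay, putting methyl in place of trifluoromethyl gives a 3.4-fold lower number from compound 2 to compound 3 (0.53 log units; beyond the scatter), so the rise in the number seen with trifluoromethyl at this saturated chain carbon is not matched in full by every group placed there. Methyl is still not equal to hydrogen at this carbon: methyl in place of hydrogen gives a 2.0-fold higher number from compound 1 to compound 3 (0.31 log units; beyond the scatter), which shows that even a group of one heavy atom moves the number beyond the usual scatter, and the three compounds now run in the order hydrogen, methyl, trifluoromethyl from the lowest number to the highest, with none going against that order among these three, while no measurement available here explains why the groups fall in this order.

Three groups at one carbon are too few to show whether the number keeps rising with larger groups, so an ethyl group or a longer chain would be a real test of that order. From the compounds shown here alone, it also remains open how a hydroxymethyl group or an amine at this same carbon would compare with hydrogen, methyl and trifluoromethyl on the shared core.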